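Swapping a meta chloro for iodo on the benzyl sulfide

A few compounds are considered here, and "the series" means these few. Any claim that something is new, unique, unknown or untested is made for them only; others in the source may bear on it.

Compound 2 `OC[C@H]1O[C@@H](n2cnc3c(SCc4cccc(Cl)c4)ncnc32)[C@H](O)[C@@H]1O` carries a 3-chlorobenzyl group on the sulfur of the shared core. Among the compounds with values here, in an assay on K562 cells for displacement of a labelled ligand from Equilibrative nucleoside transporter 1 (Homo sapiens) (a higher number here means a weaker inhibitor, a lower number a stronger inhibitor), compound 2 gives 16 nM, the highest of the two numbers measured so far. Within the data shown here, its only neighbour is compound 1 `OC[C@H]1O[C@@H](n2cnc3c(SCc4ccc(Br)cc4)ncnc32)[C@H](O)[C@@H]1O`, which in this assay gives 9.98 nM; the step of a 1.6-fold higher number from compound 1 to compound 2 (0.20 log units; within the scatter) is within the scatter, so the two cannot be told apart on these figures. Compound 3 `OC[C@H]1O[C@@H](n2cnc3c(SCc4cccc(I)c4)ncnc32)[C@H](O)[C@@H]1O` differs from compound 2 by one change: iodo in place of chloro on an aromatic carbon. Among the measured compounds shown here, no measured step isolates a halogen swap at a fixed position; the one step at hand, from compound 1 to compound 2, changed both halogen and position and stayed within the scatter. A step of no more than the scatter is therefore expected, a 1.3-fold lower number from compound 2 to compound 3 (0.12 log units; within the scatter). Compound 3 is estimated to give 12 nM, within 5 nM to 30 nM.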

Compound 3, inhibition constant: 13.8 nM
Estimate against measurement, compound 3: 1.2-fold (0.06 log units) below, within the range that was stated.
By their numbers in this assay, from the lowest: compounds 1, 3 and 2 (each within the scatter of the next).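

Within the data shown here, this is the first step that holds the position fixed and changes only the halogen: on the aromatic carbon of the benzyl ring, iodo in place of chloro gives a 1.2-fold lower number from compound 2 to compound 3 (0.06 log units; within the scatter) in this assay, so the two halogens cannot be told apart here. The step that changes both halogen and position, a 1.4-fold higher number from compound 1 to compound 3 (0.14 log units; within the scatter), also stays within the scatter, so all three halogen-bearing benzyl groups read alike in this assay. No further data bear on this result.

As far as these compounds go, all three compounds carry a single halogen on the benzyl ring, so it remains open whether an amine or a carboxylic acid on the same aromatic carbon would keep the number in this range. From the compounds shown here alone, it also remains open how a longer chain in place of the benzyl group would read.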